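The source may report more compounds than this note shows. Statements on the series, on what has been measured and on what is new or still open speak of the compounds shown alone.

Compound 1 `COc1ccc(Cn2nc(-c3ccccc3)c3cc(C(=N)Nc4cccc(C(F)(F)F)c4)ncc32)cc1` reaches only a limit of > 50000 nM in a functional assay on PC-3 cells (Homo sapiens) for cytotoxicity, read by MTT assay, with a stated time of 72 h; on this read-out lower numbers stand for stronger inhibition and higher numbers for weaker inhibition.
Compound 2 `COc1ccc(Cn2ncc3cc(C(=N)Nc4ccccc4)ncc32)cc1` gives 36000 nM in this assay.
Compound 3 `N=C(Nc1cccc(C(F)(F)F)c1)c1cc2cn[nH]c2cn1` reaches only a limit of > 50000 nM in this assay.

Compound 3 therefore stands at the edge of what this assay can report: its value is a limit, not a number, and it shares that position with compound 1, the pair making up (the limit of > 50000 nM in this assay, at which 2 of the 3 values shown sit). Only compound 2 returns a measured number, and it too sits close to that limit.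

Compound 4 `COc1ccc(Cn2ncc3cc(C(=N)Nc4cccc(C(F)(F)F)c4)ncc32)cc1` differs from compound 3 by 4-methoxybenzyl in place of hydrogen on an aromatic nitrogen. Compound 2 carries the same 4-methoxybenzyl group and gives a number rather than a limit, while compound 1, which also carries it, does not. Among the compounds with values here, no step between measured compounds is available here, so the direction of this assay change for compound 4 is open. The expected step of an at least 1.2-fold lower number from compound 3 to compound 4 (0.09 log units; that floor lies within the scatter) is small, most likely within the scatter of the method. Compound 4 is expected to give 40000 nM, between 12000 nM and 60000 nM.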

Compound 4, half-maximal inhibitory concentration: 27600 nM
Compound 4: middle estimate off by 1.4-fold (0.16 log units), on the high side, and the stated range covers the measured number.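

On these data alone, with 4-methoxybenzyl in place of hydrogen on an aromatic nitrogen, this assay shows an at least 1.8-fold lower number from compound 3 to compound 4 (0.25 log units; that floor lies within the scatter), so this change now has a limit on one side and a measured number on the other, although its true size remains unknown. Trifluoromethyl in place of hydrogen on an aromatic carbon comes with a 1.3-fold lower number from compound 2 to compound 4 (0.12 log units; within the scatter), so both compounds carrying 4-methoxybenzyl on this core without phenyl give numbers that lie within the scatter of each other. Hydrogen in place of phenyl on an aromatic carbon comes with an at least 1.8-fold lower number from compound 1 to compound 4 (0.25 log units; that floor lies within the scatter), and these steps from limits can be read only as floors: the limit of > 50000 nM in this assay, at which 2 of the 4 values shown sit.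

As far as these compounds go, it remains open whether a methyl group, a longer chain or a carboxylic acid on the same aromatic nitrogen would change the number. From the compounds shown here alone, how far compound 1 and compound 3 truly lie from compound 4 also remains open.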